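Swapping benzyl for pyridin-3-yl on the amide nitrogen

The compounds below may be only part of what the source reports. "The series", "measured", "known", "first", "only" and "open" are said of these compounds alone.

Of the compounds shown here, three sharing one core have been tested in a functional assay on the whole organism for inhibition, with Rattus norvegicus as the target, read by cytopathic effect and paw edema, at a dose of 100 mg/kg by the oral route; a lower number here means less inhibition, a higher number more inhibition at the dose given (going by the name of the read-out). Compound 1 `O=C(NCc1ccccc1)c1c(O)c2cccnc2n(-c2ccccc2)c1=O` gives 11.3%. Compound 2 `COc1cccc(NC(=O)c2c(O)c3cccnc3n(-c3ccccc3)c2=O)c1` gives 20.7%, and compound 3 `Cc1ccccc1NC(=O)c1c(O)c2cccnc2n(-c2ccccc2)c1=O` gives 9.8%. Compound 1 thus sits within the scatter of both others: a number 9.4 percentage points higher from compound 1 to compound 2 (within the scatter) and a number 1.5 percentage points lower from compound 1 to compound 3 (within the scatter), while a number 10.9 percentage points lower from compound 2 to compound 3 (beyond the scatter). Compound 4 `O=C(Nc1cccnc1)c1c(O)c2cccnc2n(-c2ccccc2)c1=O` carries pyridin-3-yl in place of benzyl on an amide-type nitrogen. The two steps that bear on this change are those that likewise exchange benzyl for an aromatic ring, and neither left the scatter, so the expected step in this assay is a number 1.7 percentage points higher from compound 1 to compound 4 (within the scatter), meaning no change beyond the scatter. Compound 4 is therefore expected to give 13%, with a range from 3% to 25%.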

Compound 4, a percentage reported as inhibition, in the whole organism at one dose (the size of the read-out at that dose, not a potency): 30.8%
Compound 4: the middle estimate sits 17.8 percentage points below what was measured, and the stated range ends below it.
By their numbers in this assay, from the lowest: compounds 3, 1 and 2 (each within the scatter of the next, the first and the last beyond it); then compound 4.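

Among the compounds shown here, on the amide-type nitrogen, pyridin-3-yl is the first group in this assay to clear the scatter upward from benzyl, with a number 19.5 percentage points higher from compound 1 to compound 4 (beyond the scatter). It also stands beyond the scatter of both other aromatic groups, with a number 21 percentage points higher from compound 3 to compound 4 (beyond the scatter) and a number 10.1 percentage points higher from compound 2 to compound 4 (beyond the scatter), making compound 4 the highest of the four. Nothing available explains this gain.

On these data alone, whether pyridin-4-yl or pyridin-2-yl at this nitrogen would match pyridin-3-yl remains open. So does whether pyridin-3-ylmethyl, which keeps the carbon link of benzyl, would carry the same gain.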